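From Bromo to Nitro in a Cell Toxicity Test

A few compounds are considered here, and "the series" means these few. Any claim that something is new, unique, unknown or untested is made for them only; others in the source may bear on it.

Among the measured compounds shown here, in an ADME assay on MT4 cells (Homo sapiens) for cytotoxicity, read by MTT assay, with a stated time of 5 days (on this read-out lower numbers stand for higher toxicity in this test and higher numbers for lower toxicity in this test), compound 3 `Cc1cc(OCC(=O)Nc2ccc(Br)cc2)nc(Nc2ccc(C#N)cc2)n1` gives 930 nM, the only true number so far. Compound 1 `N#Cc1ccc(Nc2nccc(OCC(=O)Nc3ccc([N+](=O)[O-])cc3)n2)cc1`, which also carries a nitro group, gives > 320000 nM, a limit of the assay. Compound 2 `Cc1cc(OCC(=O)Nc2ccc(F)cc2)nc(Nc2ccc(C#N)cc2)n1` gives > 331000 nM, also a limit. Compound 4 `Cc1cc(OCC(=O)Nc2ccc([N+](=O)[O-])cc2)nc(Nc2ccc(C#N)cc2)n1` differs from compound 3 by nitro in place of bromo on an aromatic carbon. For the measured compounds named here, the one measured step at this place is an at least 350-fold lower number from compound 2 to compound 3 (2.55 log units; beyond the scatter), where bromo replaced fluoro. Removing the bromo may reverse that large drop, so the expected change is a 110-fold higher number from compound 3 to compound 4 (2.03 log units; beyond the scatter), a large rise toward lower toxicity. For compound 4 the estimated value is 100000 nM, with an expected range from 5000 nM to 330000 nM.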

Compound 4, half-maximal cytotoxic concentration: > 309000 nM
Compound 4 was reported as a limit; the forecaster's own chance of this, stated with the estimate: 55%; at least 3.0-fold (0.48 log units) between middle value and limit.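

In this assay, nitro in place of bromo gives an at least 330-fold higher number from compound 3 to compound 4 (2.52 log units; beyond the scatter), so the low number of compound 3 does not carry over to this second group at the same place. Compound 4 ends at a limit of the assay, not at a true number: the limit of > 309000 nM in this assay, at which 1 of the 4 values shown sits. Of the three groups at this place, only the bromo of compound 3 gives a true number, as fluoro in compound 2 also ends at a limit, and the steps to compound 4 from compound 2 and compound 1 cannot be read.

Going by these compounds, whether chloro or an amine at this place would give a true number stays open. On these data alone, what sets bromo apart from fluoro and nitro also stays open.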